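This account rests on a few compounds, and the source may have more. Where it says the series, first, only, none or still open, it means among the compounds named here.

Measured in a functional assay on the whole organism with Mus musculus as the target, in the maximal electroshock model, at a dose of 50 mg/kg by the oral route; a lower number here means less inhibition, a higher number more inhibition at the dose given (going by the name of the read-out):
compound 1 `CCCN(CCC)CCCCOc1ccccc1/C=C/c1ccccc1`: 0%
compound 2 `CN1CCN(CCCCOc2ccccc2/C=C/c2ccc(Cl)c(Cl)c2)CC1`: 0%
compound 3 `CN1CCN(CCCCOc2ccccc2/C=C/c2ccccc2F)CC1`: 0%

Compound 1 stands level with compounds 2 and 3 at the digits shown, all three within the scatter of one another. Among the compounds with values here, the single measured step, no change at the digits printed from compound 2 to compound 3 (within the scatter), concerns only the 2-fluorophenyl in place of 3,4-dichlorophenyl on the double-bonded chain carbon. Compound 4 `O=C(O)C1CCCN(CCCCOc2ccccc2/C=C/c2ccccc2)C1` is not yet measured. Its change from compound 1 is 3-carboxypiperidin-1-yl in place of dipropylamino on a saturated chain carbon, four bonds along the chain from an oxygen on an aromatic ring. Within the data shown here, no measured step touches the dipropylamino, so the three compounds offer no ground for a shift in either direction, and all three sit at the bottom of the scale. The step expected in this assay is no change at the digits printed from compound 1 to compound 4 (within the scatter). Compound 4 is therefore estimated at 0%, with a range of 0% to 15%.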

Compound 4, a percentage reported as inhibition, in the whole organism at one dose (the size of the read-out at that dose, not a potency): 12.5%
The estimate for compound 4 lay 12.5 percentage points below the measured number, within the range that was stated.
By their numbers in this assay, from the lowest: compounds 1, 2 and 3 (each within the scatter of the next); then compound 4.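

In this assay, within the data shown here, the position four bonds along the chain from an oxygen on an aromatic ring is the first place where a change moves the read-out: 3-carboxypiperidin-1-yl in place of dipropylamino gives a number 12.5 percentage points higher from compound 1 to compound 4 (beyond the scatter) on the core of compound 1. The read-out at this position is therefore not fixed at the bottom of the scale. Nothing on hand bears on the reason for this step.

Open, as far as these compounds go, is whether the ring or the carboxylic acid carries the step. A plain piperidin-1-yl or the methyl ester of the carboxylic acid at the same place would separate the two.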